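Extending the alkyl chain on a triazolyl sugar sulfonamide

A few compounds are considered here, and "the series" means these few. Any claim that something is new, unique, unknown or untested is made for them only; others in the source may bear on it.

Measured compounds in a functional assay on RCC4 cells (Homo sapiens) for antiproliferative activity, read by XTT assay, with a stated time of 48 h; a higher number here means a weaker inhibitor, a lower number a stronger inhibitor:
compound 1, `COC(=O)CN(Cc1cn([C@@H]2O[C@H](COC(C)=O)[C@@H](OC(C)=O)[C@H]2OC(C)=O)nn1)S(C)(=O)=O`, 125000 nM;
compound 2, `CCCCN(Cc1cn([C@@H]2O[C@H](COC(C)=O)[C@@H](OC(C)=O)[C@H]2OC(C)=O)nn1)S(C)(=O)=O`, 250000 nM;
compound 3, `CCCCCCN(Cc1cn([C@@H]2O[C@H](COC(C)=O)[C@@H](OC(C)=O)[C@H]2OC(C)=O)nn1)S(C)(=O)=O`, 140000 nM.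

Compound 3 holds the second highest of the three numbers. Its nearest neighbour is compound 1, with a 1.1-fold higher number from compound 1 to compound 3 (0.05 log units; within the scatter), and its furthest is compound 2, with a 1.8-fold lower number from compound 2 to compound 3 (0.25 log units; within the scatter); neither gap separates the compounds. The three values, then, show no real spread.

Compound 4, `CCCCCCCCCCCCCCCCN(Cc1cn([C@@H]2O[C@H](COC(C)=O)[C@@H](OC(C)=O)[C@H]2OC(C)=O)nn1)S(C)(=O)=O`, differs from compound 3 by decyl in place of hydrogen on a saturated chain carbon, six bonds along the chain from a sulfonamide nitrogen; cut one bond further out, the same difference reads methyl to undecyl, ethyl to dodecyl. The step that bears most directly on it is the chain extension from compound 2 to compound 3, which gave a 1.8-fold lower number from compound 2 to compound 3 (0.25 log units; within the scatter). The two other steps, a 2.0-fold higher number from compound 1 to compound 2 (0.30 log units; within the scatter) and a 1.1-fold higher number from compound 1 to compound 3 (0.05 log units; within the scatter), swap a methoxycarbonyl for a chain and also stayed within the scatter. Among the compounds with values here, a much longer chain is untested here, so the only guide is that the small extension did not move the number beyond the scatter; a somewhat lower number is possible but not assured.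

For compound 4 the expected step is a 2.8-fold lower number from compound 3 to compound 4 (0.45 log units; beyond the scatter). Compound 4 is estimated at 50000 nM, within 10000 nM to 200000 nM.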

Compound 4, half-maximal inhibitory concentration: 13000 nM
The estimate for compound 4 lay 3.8-fold (0.59 log units) above the measured number; measured number inside the range.
By their numbers in this assay, from the lowest: compound 4; then compounds 1, 3 and 2 (each within the scatter of the next).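

In this assay, decyl in place of hydrogen on a saturated chain carbon, six bonds along the chain from a sulfonamide nitrogen, gave an 11-fold lower number from compound 3 to compound 4 (1.03 log units; beyond the scatter) and so produced the first step along this chain to pass beyond the scatter. The same holds for the full extension of the chain, which gave a 19-fold lower number from compound 2 to compound 4 (1.28 log units; beyond the scatter) where the shorter extension had given only a 1.8-fold lower number from compound 2 to compound 3 (0.25 log units; within the scatter) and thus no separation. The chain at this position can therefore move the number substantially, although among these compounds only the largest extension does so, and nothing available explains the drop.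

The compounds shown leave open whether the number falls steadily or abruptly at chain lengths intermediate between those of compound 3 and compound 4, and whether a still longer chain would lower it further. They also leave open whether a chain of similar length ending in a carboxylic acid or an amine would keep the lower number seen for compound 4.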